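The source may report more compounds than this note shows. Statements on the series, on what has been measured and on what is new or still open speak of the compounds shown alone.

Measured so far:
Compound 1, `CC(C)(Oc1ccc(F)cc1)C1OCC(C/C=C\CCC(=O)O)C(c2cccnc2)O1`, with 51 nM in an assay for inhibition of Thromboxane-A synthase (Homo sapiens), using microsomes; on this read-out higher numbers stand for weaker inhibition and lower numbers for stronger inhibition.
Compound 2, `Cc1ccc(OC(C)(C)C2OCC(C/C=C\CCC(=O)O)C(c3cccnc3)O2)cc1`, with 360 nM in this assay.
Compound 3, `CSc1ccccc1OC(C)(C)C1OCC(C/C=C\CCC(=O)O)C(c2cccnc2)O1`, with 36 nM in this assay.

Compound 3 gives the lowest of the three numbers, though its gap to compound 1 is small: a 1.4-fold lower number from compound 1 to compound 3 (0.15 log units; within the scatter), a step within the scatter. Its gap to compound 2 is larger, a 10-fold lower number from compound 2 to compound 3 (1.00 log units; beyond the scatter), and beyond the scatter. Going by the values given here, the only step that changes a substituent on the aromatic ring while keeping its attachment, a 7.1-fold higher number from compound 1 to compound 2 (0.85 log units; beyond the scatter), is modest.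

Compound 4, `CC(C)(Oc1ccc(F)cc1[N+](=O)[O-])C1OCC(C/C=C\CCC(=O)O)C(c2cccnc2)O1`, is not yet measured. The change from compound 3 is 4-fluoro-2-nitrophenyl in place of 2-(methylsulfanyl)phenyl on an oxygen on a saturated carbon. Among the compounds with values here, two measured steps bear on this: compound 3 and compound 1 differ only in the aryl group and sit within the scatter, so a 4-fluorophenyl on that oxygen is not expected to shift the number much on its own. Within the data shown here, the added nitro group has no precedent among the measured compounds, so its effect is unknown and widens the range. Compound 4 is therefore expected to land near compound 1, with a 1.5-fold higher number from compound 3 to compound 4 (0.18 log units; within the scatter) estimated as the step from compound 3. The estimate for compound 4 in this assay is 55 nM, with a range from 15 nM to 220 nM.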

Compound 4, half-maximal inhibitory concentration: 20 nM
The estimate for compound 4 lay 2.8-fold (0.44 log units) above the measured number, and the stated range covers the measured number.
By their numbers in this assay, from the lowest: compounds 4, 3 and 1 (each within the scatter of the next, the first and the last beyond it); then compound 2.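

In this assay, adding a nitro group to the aryl group on this oxygen gives a 2.6-fold lower number from compound 1 to compound 4 (0.41 log units; beyond the scatter), the first sign that a further substituent on the 4-fluorophenyl group can move the number beyond the scatter. Exchanging the whole aryl group tells a different story: 4-fluoro-2-nitrophenyl in place of 2-(methylsulfanyl)phenyl gives a 1.8-fold lower number from compound 3 to compound 4 (0.26 log units; within the scatter), so these two groups cannot be told apart here, whereas the same group in place of 4-methylphenyl gives an 18-fold lower number from compound 2 to compound 4 (1.26 log units; beyond the scatter), which widens the spread seen at this oxygen to a large step. Nothing available explains why the nitro group shifts the number on the 4-fluorophenyl group.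

Going by these compounds, the nitro group appears here only together with the fluoro group, so it remains open whether it would give a similar step on an unsubstituted phenyl or on the 4-methylphenyl group. On these data alone, it is also open whether a nitrile, a trifluoromethyl or a methoxy group in the place the nitro group holds in 4-fluoro-2-nitrophenyl would lower the number as well.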